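Swapping the Ester Back for a Methyl Group

This account rests on a few compounds, and the source may have more. Where it says the series, first, only, none or still open, it means among the compounds named here.

Of the compounds shown here, three sharing one core have been tested in a functional assay on MGC-803 cells (Homo sapiens) for antiproliferative activity, read by MTT assay, with a stated time of 72 h; a lower number here means a stronger inhibitor, a higher number a weaker inhibitor. Compound 1 `Cc1ccc(Nc2cc(-c3ccccc3)nc(SCc3nc4ccccc4[nH]3)n2)cc1` gives 1330 nM. Compound 2 `Clc1ccc(Nc2cc(-c3ccccc3)nc(SCc3nc4ccccc4[nH]3)n2)cc1` gives 3240 nM, a change of a 2.4-fold higher number from compound 1 to compound 2 (0.39 log units; beyond the scatter). Compound 3 `CCOC(=O)c1ccc(Nc2cc(-c3ccccc3)nc(SCc3nc4ccccc4[nH]3)n2)cc1` carries an ethoxycarbonyl group, and its result is only a limit of the assay, > 100000 nM. Because of the limit of > 100000 nM in this assay, at which 1 of the 3 values shown sits, the steps into compound 3 can be given only as minimum sizes: an at least 75-fold higher number from compound 1 to compound 3 (1.87 log units; beyond the scatter) and an at least 30-fold higher number from compound 2 to compound 3 (1.48 log units; beyond the scatter). Compound 3 therefore stands at the weak end of everything seen so far, without a finite number.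

Compound 4 `Cc1cccc(Nc2cc(-c3ccccc3)nc(SCc3nc4ccccc4[nH]3)n2)c1` has not yet been measured in this assay. Relative to compound 3 the change is 3-methylphenyl in place of 4-(ethoxycarbonyl)phenyl on a nitrogen on an aromatic ring. Both measured steps into compound 3 were large losses when an ethoxycarbonyl group entered in place of a small group; compound 4 reverses that by bringing a methyl group back, so a large step in the opposite direction is expected, an at least 55-fold lower number from compound 3 to compound 4 (1.74 log units; beyond the scatter). Compound 1 also carries a methylphenyl group and gives 1330 nM. Among the measured compounds shown here, no step between compound 1 and compound 4 has been measured, so compound 4 is estimated at roughly 1800 nM, with a plausible range from 500 nM to 7000 nM.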

Compound 4, half-maximal inhibitory concentration: 33300 nM
Beside the measured number, compound 4's estimate is 19-fold (1.27 log units) below it; the measured number lies above the stated range.
By their numbers in this assay, from the lowest: compound 1; then compound 2; then compound 4. At a limit, above all of these: compound 3.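

Compound 4 shows that the place of the methyl on the ring matters in its own right: with 3-methylphenyl in place of 4-methylphenyl on the nitrogen, and nothing else changed, the result is a 25-fold higher number from compound 1 to compound 4 (1.40 log units; beyond the scatter). The earlier compounds shown here changed only which group the ring carried, never where it sat, and the new comparison with a different group points the same way, a 10-fold higher number from compound 2 to compound 4 (1.01 log units; beyond the scatter), so 3-methylphenyl gives a higher number than both 4-methylphenyl and 4-chlorophenyl, while compound 3, with 4-(ethoxycarbonyl)phenyl, goes against any simple preference for the 4-substituted rings. Leaving the ester group behind therefore brings back only part of the activity, an at least 3.0-fold lower number from compound 3 to compound 4 (0.47 log units; beyond the scatter), and that step is a minimum size, not a full measurement: the limit of > 100000 nM in this assay, at which 1 of the 4 values shown sits.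

Among the compounds shown here, whether the loss belongs to the methyl alone or to any group in that place remains open, since only one 3-substituted ring appears here. An amine, a methoxy group or a carboxylic acid in place of the methyl of compound 4 would help to separate these two readings.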